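Chloro-to-fluoro swap in a succinimide propanamide series

This account rests on a few compounds, and the source may have more. Where it says the series, first, only, none or still open, it means among the compounds named here.

Measured so far:
compound 1, `CC(C(=O)NCc1ccccc1Cl)N1C(=O)CCC1=O`, 74.5 mg/kg
compound 2, `CC(C(=O)NCc1cccc(Cl)c1)N1C(=O)CCC1=O`, 82 mg/kg
compound 3, `CC(C(=O)NCc1ccc(Cl)cc1)N1C(=O)CCC1=O`, 91.8 mg/kg

All three values come from a functional assay on the whole organism (strain Albino Swiss CD1) with Mus musculus as the target, in the maximal electroshock model; a lower number here means that less compound is needed, a higher number that more compound is needed for the effect. In this assay compound 1 gives 74.5 mg/kg, compound 2 gives 82 mg/kg and compound 3 gives 91.8 mg/kg. The three numbers fall inside the usual scatter of one another: compound 2 sits closest to compound 1 and furthest from compound 3, yet neither gap is large enough to be called a real difference. Among the compounds with values here, the set therefore gives no measured step that could guide an expectation; the position of the chloro group around the ring shows no effect that stands out from the noise.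

Compound 4, `CC(C(=O)NCc1cccc(F)c1)N1C(=O)CCC1=O`, is not yet measured. It differs from compound 2 by fluoro in place of chloro on an aromatic carbon. Within the data shown here, with no measured pair showing what this exchange does in this assay, the expectation is of no step beyond the scatter, with a slight lean toward a somewhat larger dose. The step from compound 2 is therefore estimated as a 1.2-fold higher number from compound 2 to compound 4 (0.06 log units; within the scatter). For compound 4 in this assay the estimated value is 95 mg/kg, with a range from 50 mg/kg to 180 mg/kg.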

Compound 4, dose for half-maximal effect: 77.4 mg/kg
Beside the measured number, compound 4's estimate is 1.2-fold (0.09 log units) above it; the range from low to high includes it.
By their numbers in this assay, from the lowest: compounds 1, 4, 2 and 3 (each within the scatter of the next).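

In this assay, within the data shown here, fluoro in place of chloro on the aromatic carbon meta to a large group gives a 1.1-fold lower number from compound 2 to compound 4 (0.03 log units; within the scatter) and so provides the first measured pair for this exchange. The earlier compounds shown here varied only where chloro sits on the ring, whereas this pair changes the halogen itself at a single place, and the result shows that this place accepts fluoro or chloro without a step that can be separated from the noise. The reading is limited to this one place and this one exchange, and nothing measured alongside these compounds bears on what lies behind the result.

Still open, going by these compounds, is whether a group of a different kind at this place, such as an amine, a carboxylic acid, a nitrile or a trifluoromethyl group, would produce a step beyond the scatter, and how the compound with only hydrogen here would compare. The compounds shown also leave open whether fluoro behaves the same way at other places on the ring, and whether a longer chain in place of the methyl group on the shared core would change the dose needed.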